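From 2-nitrophenyl to 4-fluorophenyl on a sulfonyl sulfur

A few compounds are considered here, and "the series" means these few. Any claim that something is new, unique, unknown or untested is made for them only; others in the source may bear on it.

Values so far in a functional assay on RS4-11 cells (Homo sapiens) for inhibition, read by CCK-8 assay, with a stated time of 48 h, tested at 20 uM; on this read-out lower numbers stand for less inhibition of growth and higher numbers for more inhibition of growth at the one concentration tested
- compound 1 `COc1ccc(Cc2nnc(NC(=O)/C(C#N)=C/c3ccccc3OS(=O)(=O)c3ccc(F)cc3)s2)cc1` gives 80%
- compound 2 `N#C/C(=C\c1ccccc1OS(=O)(=O)c1ccccc1[N+](=O)[O-])C(=O)Nc1nnc(Cc2ccccc2)s1` gives 71%

Among the compounds with values here, only two compounds have been measured, and compound 2 lies within the usual scatter of compound 1, so these numbers do not separate the two. Compound 3 `N#C/C(=C\c1ccccc1OS(=O)(=O)c1ccc(F)cc1)C(=O)Nc1nnc(Cc2ccccc2)s1` is built from compound 2 by one change: 4-fluorophenyl in place of 2-nitrophenyl on a sulfonyl sulfur. Within the data shown here, no measured pair shows this change on its own, so the data give only a loose guide to what it does in this assay. Among the measured compounds shown here, the one clue is compound 1, which also carries 4-fluorophenyl on a sulfonyl sulfur and gives 80% in that test. Resting on that value, a small rise is expected, but nothing beyond the scatter. The estimated step of a number 5 percentage points higher from compound 2 to compound 3 (within the scatter) is therefore not expected to be a clear one. Compound 3 is estimated at 76% within an expected range (60% to 90%).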

Compound 3, percent growth inhibition at one concentration: 69%
Estimate against measurement, compound 3: 7 percentage points above; the range from low to high includes it.
By their numbers in this assay, from the lowest: compounds 3, 2 and 1 (each within the scatter of the next, the first and the last beyond it).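

In this assay, putting 4-fluorophenyl in place of 2-nitrophenyl on a sulfonyl sulfur gives a number 2 percentage points lower from compound 2 to compound 3 (within the scatter) and so leaves no measurable mark: at this position, these two groups cannot be told apart, although they differ in size and the nitro group's hydrogen-bond acceptors are lost. Within the data shown here, compound 3 also gives the first pair that isolates the methoxy group, and hydrogen in place of methoxy on an aromatic carbon gives a number 11 percentage points lower from compound 1 to compound 3 (beyond the scatter) as a modest step, the only single change so far that lies beyond the usual scatter. Nothing available explains either step.

Among these compounds, only two aryl groups have been compared on the sulfonyl sulfur, so it remains open whether a phenyl ring carrying an amine or a carboxylic acid, or a plain methyl group in place of the ring, would give similar growth inhibition. The methoxy result also rests on one pair at one concentration, and it is unclear how an ethoxy group, a longer chain or a hydroxyl group in its place would read.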